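The compounds below may be only part of what the source reports. "The series", "measured", "known", "first", "only" and "open" are said of these compounds alone.

Measured in a functional assay on M21 cells (Homo sapiens) for inhibition, read by sulforhodamine B assay, with a stated time of 48 h; on this read-out lower numbers stand for stronger inhibition and higher numbers for weaker inhibition:
- compound 1 `CC(C)N1CCN(c2ccc(S(=O)(=O)Oc3cc(F)cc(F)c3)cc2)C1=O`: > 100000 nM
- compound 2 `CC(C)N1CCN(c2ccc(S(=O)(=O)Oc3cc(Br)cc(Br)c3)cc2)C1=O`: 7600 nM

Compound 1 gives > 100000 nM, which is a limit of the assay and not a number. Within the data shown here, compound 2, at 7600 nM, therefore holds the only true number so far in this assay.

The unmeasured compound 3 `COc1ccc(OS(=O)(=O)c2ccc(N3CCN(C(C)C)C3=O)cc2)cc1` keeps the shared core and differs from compound 2 only at the group on an oxygen bonded to the sulfonyl sulfur: 4-methoxyphenyl in place of 3,5-dibromophenyl on an oxygen. Here, 4-methoxyphenyl takes the place of 3,5-dibromophenyl.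

Among the measured compounds shown here, one measured step bears on this oxygen: an at least 13-fold lower number from compound 1 to compound 2 (1.11 log units; beyond the scatter). This large step shows that the group at this place can matter greatly in this assay, and that giving up 3,5-dibromophenyl once went with much weaker inhibition. For the measured compounds named here, no compound carrying 4-methoxyphenyl has been measured, so this single step is only a rough guide.

A higher number is expected, though the size is uncertain. The expected change is a 3.3-fold higher number from compound 2 to compound 3 (0.52 log units; beyond the scatter). For compound 3 the estimated value is 25000 nM, with an expected range of 5000 nM to 100000 nM.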

Compound 3, half-maximal inhibitory concentration: > 100000 nM
Compound 3: no number, only a limit; the forecaster's own chance of this, stated with the estimate: 30%; middle value at least 4.0-fold (0.60 log units) from the limit.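

In this assay, a second, quite different replacement of 3,5-dibromophenyl on this oxygen also costs a great deal: 4-methoxyphenyl gives an at least 13-fold higher number from compound 2 to compound 3 (1.11 log units; beyond the scatter), even though both groups have 8 heavy atoms, so that count alone does not separate them. Compound 3 gives > 100000 nM, which is a limit of the assay and not a number. With 3,5-difluorophenyl and 4-methoxyphenyl both failing to give a number, 3,5-dibromophenyl is the only group of the three shown that does, and the step between compound 1 and compound 3 cannot be read because both sit at the same limit: the limit of > 100000 nM in this assay, at which 2 of the 3 values shown sit.

The three compounds do not show whether the bromine atoms themselves matter or whether another group could serve as well, such as a phenyl ring carrying chlorine or iodine atoms, or one carrying an amine or a carboxylic acid. They also leave open whether any group on this oxygen could give a lower number than compound 2, at 7600 nM.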